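The compounds below may be only part of what the source reports. "The series", "measured", "known", "first", "only" and "open" are said of these compounds alone.

Compound 1 `O=C1CSC(N2N=C(c3ccc(Cl)cc3)CC2c2cccc3ccccc23)=N1`: 8840 nM
Compound 2 `O=C1CSC(N2N=C(c3ccc(F)cc3)CC2c2cccc3ccccc23)=N1`: 11300 nM
Compound 3 `Brc1ccc(C2=NN(C3=NC(c4ccccc4)CS3)C(c3cccc4ccccc34)C2)cc1`: 6650 nM

In a functional assay on HeLa cells (Homo sapiens) for inhibition, read by CCK-8 assay, with a stated time of 48 h (on this read-out higher numbers stand for weaker inhibition and lower numbers for stronger inhibition), compound 3 gives 6650 nM, a value within the usual scatter of those of compound 1 and compound 2, so the three cannot be ranked. Compound 4 `O=C1CSC(N2N=C(c3ccc(Br)cc3)CC2c2cccc3ccccc23)=N1` keeps the 4-bromophenyl group and the naphthalen-1-yl group of compound 3 but changes the group on an amine nitrogen in a ring: a group of 6 heavy atoms (3 carbon, 1 nitrogen, 1 oxygen, 1 sulfur; one five-membered non-aromatic ring with 2 hetero atoms) in place of a group of 11 heavy atoms (9 carbon, 1 nitrogen, 1 sulfur; one five-membered non-aromatic ring with 2 hetero atoms, one six-membered aromatic ring of carbon only), on an amine nitrogen in a ring. For the measured compounds named here, no measured step covers this exact exchange. The only one available, a 1.3-fold higher number from compound 1 to compound 2 (0.11 log units; within the scatter), concerns the halogen on the aromatic carbon, and it is small. The entering group is already present in compound 1 at 8840 nM and in compound 2 at 11300 nM, and these values sit close to that of compound 3. No step beyond the scatter is therefore expected in this assay. Compound 4 is expected at 8500 nM, with an estimated range of 4800 nM to 15000 nM. The estimated change is a 1.3-fold higher number from compound 3 to compound 4 (0.11 log units; within the scatter).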

Compound 4, half-maximal inhibitory concentration: 5810 nM
Beside the measured number, compound 4's estimate is 1.5-fold (0.17 log units) above it; low and high end bracket the measured number.
By their numbers in this assay, from the lowest: compounds 4, 3, 1 and 2 (each within the scatter of the next).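

In this assay the step at the amine nitrogen in a ring is a 1.1-fold lower number from compound 3 to compound 4 (0.06 log units; within the scatter), so within this series a group of 11 heavy atoms with a six-membered aromatic ring of carbon only and a group of 6 heavy atoms without that ring cannot be told apart at this position. The halogen on the aromatic carbon adds the same message, with a 1.9-fold lower number from compound 2 to compound 4 (0.29 log units; within the scatter) and a 1.5-fold lower number from compound 1 to compound 4 (0.18 log units; within the scatter), so bromo, chloro and fluoro cannot be separated here either. No measurement is available to explain these results.

As far as these compounds go, whether an amine or a carboxylic acid on the five-membered ring at this position would give a step beyond the scatter remains open. So does the effect of a methoxy group in place of the halogen.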